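The compounds below may be only part of what the source reports. "The series", "measured", "known", "first", "only" and "open" are said of these compounds alone.

Compound 1 `O=C(O)c1cccc(S(=O)(=O)N2CCC(NS(=O)(=O)c3cc(S(=O)(=O)c4ccccc4)ccc3C(F)(F)F)CC2)c1` carries a sulfonyl-linked amide on a shared core. In an assay on U2OS cells for inhibition of secreted frizzled-related protein 1 (Homo sapiens), read by a luciferase reporter, with a stated time of 18 h (a lower number here means that less compound is needed, a higher number that more compound is needed for the effect), compound 1 gives 190 nM. For the measured compounds named here, the only other measured compound, compound 2 `CC(C)(C)OC(=O)N1CCC(CC(=O)N2CCC(NS(=O)(=O)c3cc(S(=O)(=O)c4ccccc4)ccc3C(F)(F)F)CC2)CC1`, gives 400 nM in this assay, so compound 1 has the lower of the two numbers, and the gap between them lies beyond the usual scatter of repeated measurements.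

Compound 3 `O=C([C@H]1CCNC1)N1CCC(NS(=O)(=O)c2cc(S(=O)(=O)c3ccccc3)ccc2C(F)(F)F)CC1` has not yet been measured. The change from compound 1 to compound 3 is (pyrrolidin-3-yl)carbonyl in place of (3-carboxyphenyl)sulfonyl on an amine nitrogen in a ring. Compound 2 shows that exchanging the sulfonyl-linked group on this ring nitrogen for a carbonyl-linked one can raise the number, and compound 3 makes an exchange of the same kind. A moderate rise in this assay is therefore expected for compound 3, of about a 1.8-fold higher number from compound 1 to compound 3 (0.27 log units; within the scatter), though it could also stay within the scatter. Compound 3 is estimated at 350 nM, with a likely range from 130 nM to 1000 nM.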

Compound 3, half-maximal effective concentration: 700 nM
The estimate for compound 3 lay 2.0-fold (0.30 log units) below the measured number; measured number inside the range.
By their numbers in this assay, from the lowest: compound 1; then compounds 2 and 3 (each within the scatter of the next).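

Compound 1 and compound 3 differ only at an amine nitrogen in a ring. For the compounds shown here, they give the first direct reading of this position. In this assay, putting (pyrrolidin-3-yl)carbonyl in place of (3-carboxyphenyl)sulfonyl gives a 3.7-fold higher number from compound 1 to compound 3 (0.57 log units; beyond the scatter), a modest step beyond the scatter, and compound 3 still reaches an effect at 700 nM in this assay, so the six-membered aromatic ring of the leaving group is not required for a measurable effect here. No measurement offered here accounts for this step.

The linking sulfonyl, the ring and the carboxylic acid all change together, so their separate shares cannot be read from this pair. On these data alone, a (3-carboxyphenyl)carbonyl group on the same nitrogen would separate the linking group from the ring, and the opposite stereocentre of the (pyrrolidin-3-yl)carbonyl group also remains open.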